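Toward Compound 4: a Methyl Instead of Chlorine on the Aryl Group

The source may hold more compounds than are shown below. What is called first, only, known or untested is meant among the compounds shown, and "the series" means these compounds.

Compound 3 `Cc1c(C(=O)NCc2cccc(C(F)(F)F)c2)cnn1-c1ccccc1Cl` carries a 2-chlorophenyl group on an aromatic nitrogen of the shared core. In a functional assay on cells for antagonist activity at C-C chemokine receptor type 1 (Homo sapiens), read by FLIPR and calcium flux (a lower number here means a stronger inhibitor, a higher number a weaker inhibitor), compound 3 returns only a limit of the assay, > 3000 nM. Compound 1 `Cc1c(C(=O)NCc2cccc(C(F)(F)F)c2)cnn1-c1ccc(Cl)c(Cl)c1`, with 3,4-dichlorophenyl in that place, gives 500 nM. Compound 2 `Cc1c(C(=O)NCc2cccc(C(F)(F)F)c2)cnn1-c1ccccc1`, with plain phenyl, also sits at a limit, > 3000 nM. Two of the three values therefore rest at the limit of > 3000 nM in this assay, at which 2 of the 3 values shown sit. Both an at least 6.0-fold higher number from compound 1 to compound 3 (0.77 log units; beyond the scatter) and an at least 6.0-fold higher number from compound 1 to compound 2 (0.77 log units; beyond the scatter) show that leaving the 3,4-dichlorophenyl of compound 1 costs potency, whereas a step that the two limits leave unreadable from compound 2 to compound 3 cannot be read between the two limits. Compound 4 `Cc1cccc(-n2ncc(C(=O)NCc3cccc(C(F)(F)F)c3)c2C)c1` is compound 3 with 3-methylphenyl in place of 2-chlorophenyl on an aromatic nitrogen. A 3-methylphenyl group is not the 3,4-dichlorophenyl of compound 1, yet it is also not the plain phenyl of compound 2 or the 2-chlorophenyl of compound 3, so a small gain is expected but without reaching compound 1. The expected change is an at least 1.2-fold lower number from compound 3 to compound 4 (0.07 log units; that floor lies within the scatter). Compound 4 is estimated at 2500 nM, within a range from 600 nM to 10000 nM.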

Compound 4, half-maximal inhibitory concentration: > 3000 nM
Compound 4 ended at the assay's limit (the forecaster's own chance of this, stated with the estimate: 45%); middle value at least 1.2-fold (0.07 log units) away from the limit.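

In this assay a single methyl on the aryl group, as in the 3-methylphenyl of compound 4, does not bring the compound into the readable range, and a third aryl group now rests at the limit: the limit of > 3000 nM in this assay, at which 3 of the 4 values shown sit.

Among the four aryl groups, only the 3,4-dichlorophenyl of compound 1 gives a readable number, and replacing it with 3-methylphenyl costs potency, with an at least 6.0-fold higher number from compound 1 to compound 4 (0.77 log units; beyond the scatter). The steps to compound 4 from compound 2 and from compound 3 cannot be read, as both ends of each are limits.

From the compounds shown here alone, it remains open whether 3-chlorophenyl or 4-chlorophenyl alone would give a readable number. Going by these compounds, it also remains open whether 3,4-dimethylphenyl would come close to compound 1, which would separate the two methyl groups from the two chlorines.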